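A few compounds are considered here, and "the series" means these few. Any claim that something is new, unique, unknown or untested is made for them only; others in the source may bear on it.

Measured in an ADME assay on the whole organism with Oryza sativa as the target, tested at 1 uM; a higher number here means a weaker effect of the compound at the concentration tested, a lower number a stronger effect:
compound 1 `CC(=O)c1cccc(NC(=O)N[C@@H](C)c2ccccc2)c1` gives 95%
compound 2 `C[C@H](NC(=O)Nc1cccc(F)c1)c1ccccc1` gives 94%
compound 3 `C[C@H](NC(=O)Nc1cccc(Br)c1)c1ccccc1` gives 100%

Compound 2 holds the lowest of the three numbers in this assay, but one of the two gaps around it is a number 1 percentage points lower from compound 1 to compound 2 (within the scatter) and the other is a number 6 percentage points higher from compound 2 to compound 3 (within the scatter), so the three compounds cannot be separated on these data. The step from compound 1 to compound 3 is likewise a number 5 percentage points higher from compound 1 to compound 3 (within the scatter).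

Compound 4 `C[C@H](NC(=O)Nc1cccc(F)c1F)c1ccccc1` differs from compound 2 by fluoro in place of hydrogen on an aromatic carbon. Within the data shown here, no measured pair repeats this exact change, so there is no direct precedent. The closest comparison comes from the three measured steps, each of which exchanges one group on the shared core for another and each of which stays within the scatter, the largest being a number 6 percentage points higher from compound 2 to compound 3 (within the scatter). Three substituent exchanges on this part of the core have left this assay unmoved beyond the scatter, and a further fluoro in place of hydrogen is expected to behave the same way: the expected step from compound 2 is a number 1 percentage points higher from compound 2 to compound 4 (within the scatter), that is, no step beyond the scatter in either direction. Compound 4 is therefore estimated at 95%, with a range from 85% to 100%, bearing in mind that the whole set so far sits near the top of the scale.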

Compound 4, a percentage reported as activity, at one concentration (the size of the read-out at that concentration, not a potency): 100%
Beside the measured number, compound 4's estimate is 5 percentage points below it, and the stated range covers the measured number.
By their numbers in this assay, from the lowest: compounds 2, 1, 3 and 4 (each within the scatter of the next).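

In this assay, adding a group where a hydrogen stood, rather than exchanging one group for another, gives a number 6 percentage points higher from compound 2 to compound 4 (within the scatter), so fluoro on this aromatic carbon, ortho to a fluoro group and ortho to a large group, produces no step beyond the scatter. Among the compounds shown, compound 4 is the only one with this position filled and the only one carrying two fluoro groups, which extends the flat picture in this assay from exchanges of one substituent for another to the addition of a second substituent on the same aromatic ring. No measurement shown bears on why this change leaves the number within the scatter.

The compounds shown leave open whether a larger group at this position, such as methoxy, an amine, a carboxylic acid or a longer chain, would produce a step beyond the scatter in this assay. They also leave open whether any change elsewhere on the shared core would separate compounds that so far cannot be told apart, since every step read here stays within the scatter.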